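The source may hold more compounds than are shown below. What is called first, only, known or untested is meant among the compounds shown, and "the series" means these compounds.

Measured compounds:
- compound 1 `COc1ccc(C(/C=C/c2cccs2)=N/O)cc1` gives 8490 nM in a functional assay (Mus musculus, strain Balb/c) for inhibition, read by ELISA, with a stated time of 72 h; on this read-out lower numbers stand for stronger inhibition and higher numbers for weaker inhibition
- compound 2 `COc1ccc(C(/C=C/c2ccccc2)=N/O)cc1` gives 11800 nM in this assay

Within the data shown here, compound 1 has the lowest of the two numbers measured so far in this assay, but its nearest neighbour, compound 2, differs from it only by a 1.4-fold higher number from compound 1 to compound 2 (0.14 log units; within the scatter), so the two values cannot be told apart.

Compound 3 `O/N=C(\C=C\c1cccs1)c1ccc(Cl)cc1` has not yet been measured. It differs from compound 1 by a single change: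
chloro in place of methoxy on an aromatic carbon

Among the measured compounds shown here, the one measured step, from compound 1 to compound 2, concerns the aryl group on the double-bonded chain carbon, not the six-membered aromatic ring that carries the methoxy group, so no measured step bears directly on the change from compound 1 to compound 3. For the measured compounds named here, the only guidance available is that the sole variation recorded so far, a 1.4-fold higher number from compound 1 to compound 2 (0.14 log units; within the scatter), stayed within the scatter. On that basis the number for compound 3 in this assay is expected to stay close to that of compound 1, with a step of about a 1.1-fold lower number from compound 1 to compound 3 (0.03 log units; within the scatter) expected, in no particular direction. The estimate for compound 3 is therefore 8000 nM, with a range from 3000 nM to 22000 nM.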

Compound 3, half-maximal inhibitory concentration: 9590 nM
Estimate against measurement, compound 3: 1.2-fold (0.08 log units) below; measured number inside the range.
By their numbers in this assay, from the lowest: compounds 1, 3 and 2 (each within the scatter of the next).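

Chloro in place of methoxy, on an aromatic carbon para to a large group, is the first measured change at this position, and in this assay it gives a 1.1-fold higher number from compound 1 to compound 3 (0.05 log units; within the scatter). The change removes a group of two heavy atoms with one hydrogen-bond acceptor and puts in a single chlorine with none, yet the number does not move beyond the scatter, so this exchange has no readable effect at this position. No measurement shown here bears on why this is so.

On these data alone, with the three compounds each within the scatter of the next, it remains open whether any group at this position can move the number beyond the scatter, for instance an amine, a carboxylic acid or a longer chain such as butoxy in place of methoxy. Among these compounds, it is also open whether chloro would give the same result in the compound that carries phenyl in place of thiophen-2-yl, since the only step for that exchange, a 1.4-fold higher number from compound 1 to compound 2 (0.14 log units; within the scatter), was read with methoxy in place.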